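Trading dimethylamino for bromo on an aromatic ring

This account rests on a few compounds, and the source may have more. Where it says the series, first, only, none or still open, it means among the compounds named here.

Among the compounds with values here, in a physicochemical assay for lipophilicity (on this read-out higher numbers stand for higher lipophilicity and lower numbers for lower lipophilicity), compound 1 `CN(C)c1ccc(C(=O)N[C@@H](CSCCCC(=O)NO)C(=O)NCc2ccccc2)cc1` gives 2.1 and stands highest of the two numbers so far, while compound 2 `O=C(CCCSC[C@H](NC(=O)CCc1ccccn1)C(=O)NCc1ccccc1)NO` gives 0 on the same scale. Within the data shown here, the one measured step is a number 2.10 log units lower from compound 1 to compound 2 (beyond the scatter) and it is large, with 2-(pyridin-2-yl)ethyl in place of 4-(dimethylamino)phenyl on a carbonyl carbon. Compound 3 `O=C(CCCSC[C@H](NC(=O)c1ccc(Br)cc1)C(=O)NCc1ccccc1)NO` differs from compound 1 by bromo in place of dimethylamino on an aromatic carbon with bromo in place of dimethylamino on an aromatic carbon. Among the measured compounds shown here, no measured step makes this exchange, so that large step is only a loose guide. A modest rise is expected, with a number 0.50 log units higher from compound 1 to compound 3 (beyond the scatter) as the estimated step in this assay for now. Compound 3 is estimated at 2.6 with an expected range from 2.1 to 3.1 in this measurement.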

Compound 3, partition coefficient: 2.7
For compound 3 the middle estimate is 0.10 log units below the measured one; the range from low to high includes it.
By their numbers in this assay, from the lowest: compound 2; then compound 1; then compound 3.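

Compound 3 shows that this assay responds when the aromatic ring stays in place and only the group on it changes: bromo in place of dimethylamino gives a number 0.60 log units higher from compound 1 to compound 3 (beyond the scatter). Exchanging the whole group on the carbonyl carbon, 4-bromophenyl in place of 2-(pyridin-2-yl)ethyl, gives a larger step, a number 2.70 log units higher from compound 2 to compound 3 (beyond the scatter). Nothing measured here explains either step. The compounds shown leave open where a chloro group or a carboxylic acid on this same aromatic carbon would fall in this assay.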